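Swapping the aryl on the triazole nitrogen

The source may report more compounds than this note shows. Statements on the series, on what has been measured and on what is new or still open speak of the compounds shown alone.

Compound 1 is `Cc1ccc(-n2cc(-c3ccccc3NS(=O)(=O)c3c[nH]c(=O)[nH]c3=O)nn2)cc1`; in an ADME assay on GES1 cells (Homo sapiens) for cytotoxicity, read by MTT assay, with a stated time of 24 h (a lower number here means that less compound is tolerated, a higher number that more compound is tolerated), compound 1 gives 32400 nM.
Compound 2 is `O=c1[nH]cc(S(=O)(=O)Nc2ccccc2-c2cn(-c3ccccc3F)nn2)c(=O)[nH]1`; in this assay compound 2 gives > 100000 nM, which is a limit of the assay and not a number.
Compound 3 is `Cc1ccccc1-n1cc(-c2cccc(NS(=O)(=O)c3c[nH]c(=O)[nH]c3=O)c2)nn1`; in this assay compound 3 gives 21500 nM.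

Among the two numbers shown, compound 3 sits lowest, but its nearest neighbour is compound 1, and the gap between them lies within the scatter of this kind of measurement. The third value belongs to compound 2 and is a limit, so it cannot be placed on the same scale.

Compound 4 is `O=c1[nH]cc(S(=O)(=O)Nc2cccc(-c3cn(-c4ccc(F)cc4)nn3)c2)c(=O)[nH]1`. It differs from compound 3 by 4-fluorophenyl in place of 2-methylphenyl on an aromatic nitrogen. Among the measured compounds shown here, one measured step bears on this change: an at least 3.0-fold higher number from compound 1 to compound 2 (0.48 log units; beyond the scatter), where a methylphenyl on the same aromatic nitrogen was also exchanged for a fluorophenyl, though the substituents sat at different positions of the phenyl ring. That step ran toward a higher number and reached the assay limit, described by the limit of > 100000 nM in this assay, at which 1 of the 3 values shown sits. The exchange in compound 4 is of the same kind, so a modest rise in this assay is expected, possibly again up to the limit, giving an expected step of a 2.6-fold higher number from compound 3 to compound 4 (0.41 log units; beyond the scatter). For compound 4 the estimate is 55000 nM, within 22000 nM to 140000 nM.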

Compound 4, half-maximal cytotoxic concentration: "not toxic" (no number reported)
The entry for compound 4 holds no number; there is nothing to compare the estimate with.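

In this assay, among the compounds shown here, compound 4 is entered only as "not toxic", with no number, so no step from compound 3 to compound 4 can be read. The compounds shown leave open whether 4-fluorophenyl in place of 2-methylphenyl changes the tolerated concentration, and how compound 4 stands against the one limit in the set: the limit of > 100000 nM in this assay, at which 1 of the 4 values shown sits.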